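Working notes: hydrogen in place of phenyl in compound 1

The source may report more compounds than this note shows. Statements on the series, on what has been measured and on what is new or still open speak of the compounds shown alone.

Measured in a physicochemical assay for acid dissociation
- Compound 1 (`CCOC(=O)c1nnn(Cc2ccccc2)c1O`) gives 6.22
- Compound 2 (`CCOC(=O)c1c(O)nnn1Cc1ccccc1`) gives 5.38

Compound 1 stands higher of the two in this assay, and the gap down to compound 2 lies beyond the usual scatter. Compound 3 (`CCOC(=O)c1nnn(C)c1O`) has not yet been measured. It differs from compound 1 by a single change: hydrogen in place of phenyl on a saturated chain carbon bound to an aromatic nitrogen. Among the compounds with values here, no measured pair of compounds shows this change, so the expectation is a judgement without a direct precedent. No step beyond the scatter is expected in either direction. The expected step is a number 0.08 log units higher from compound 1 to compound 3 (within the scatter). For compound 3 the estimate is 6.3, with an expected range from 5.9 to 6.7.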

Compound 3, acid dissociation constant: 6.21
Compound 3: middle estimate off by 0.09 log units, on the high side, within the range that was stated.
By their numbers in this assay, from the lowest: compound 2; then compounds 3 and 1 (each within the scatter of the next).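

In this assay, hydrogen in place of phenyl on a saturated chain carbon bound to an aromatic nitrogen gives a number 0.01 log units lower from compound 1 to compound 3 (within the scatter). Within the data shown here, this pair is the first direct reading of the change, and it shows that a six-membered aromatic ring of carbon only can leave this place with the read-out staying within the scatter. No supporting evidence bears on why the two values agree.

This one pair covers only phenyl and hydrogen at this place, so a carboxylic acid, an amine or a longer chain on the same saturated chain carbon could still give a step beyond the scatter. Going by these compounds, whether hydrogen in place of phenyl gives a similar step on the core of compound 2 also remains open.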